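The compounds below may be only part of what the source reports. "The series", "measured", "known", "first", "only" and "open" are said of these compounds alone.

Measured so far:
Compound 1 `CC(=O)N[C@@H]1CCC[C@H](C(=O)Nc2cc(-c3cnn4c3CCCCC4)c(Cl)cn2)C1` — 51 uL/min
Compound 2 `CC(=O)N[C@@H]1CCC[C@H](C(=O)Nc2cc(-c3cnn4c3CN(C)CC4)c(Cl)cn2)C1` — 7.7 uL/min
Compound 3 `CC(=O)N[C@@H]1CCC[C@H](C(=O)Nc2cc(-c3cnn4c3NCCC4)c(Cl)cn2)C1` — 10 uL/min

In an ADME assay on cells (Hepatocyte, Rattus norvegicus) for metabolic stability, using equilibrium dialysis (a higher number here means faster removal of the compound, a lower number slower removal), compound 3 gives 10 uL/min, the second highest of the three numbers. Its nearest neighbour is compound 2, a step of a 1.3-fold higher number from compound 2 to compound 3 (0.11 log units; within the scatter); the furthest is compound 1, a step of a 5.1-fold lower number from compound 1 to compound 3 (0.71 log units; beyond the scatter).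

Compound 4 `CC(=O)N[C@@H]1CCC[C@H](C(=O)Nc2cc(-c3cnn4c3OCCC4)c(Cl)cn2)C1` is not yet measured. Its change from compound 3 is a group of 9 heavy atoms (6 carbon, 2 nitrogen, 1 oxygen; one five-membered aromatic ring with 2 hetero atoms, one six-membered non-aromatic ring with 2 hetero atoms) in place of a group of 9 heavy atoms (6 carbon, 3 nitrogen; one five-membered aromatic ring with 2 hetero atoms, one six-membered non-aromatic ring with 2 hetero atoms), on an aromatic carbon.

The step that bears most on this is a 1.3-fold higher number from compound 2 to compound 3 (0.11 log units; within the scatter), where the fused six-membered ring was also varied and the number stayed within the scatter. The larger steps of a 6.6-fold lower number from compound 1 to compound 2 (0.82 log units; beyond the scatter) and a 5.1-fold lower number from compound 1 to compound 3 (0.71 log units; beyond the scatter) both involved the seven-membered ring, which compound 4 does not have. A step of a 1.2-fold higher number from compound 3 to compound 4 (0.08 log units; within the scatter) is therefore expected, within the scatter. Compound 4 is estimated at 12 uL/min, between 6 uL/min and 25 uL/min.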

Compound 4, intrinsic clearance in a liver preparation (reported as CLH), per the amount of preparation that the assay uses in the Hepatocyte assay: 34 uL/min
The estimate for compound 4 lay 2.8-fold (0.45 log units) below the measured number; measured number outside the range, above it.
By their numbers in the Hepatocyte assay, from the lowest: compounds 2 and 3 (each within the scatter of the next); then compounds 4 and 1 (each within the scatter of the next).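

Changing one ring atom from nitrogen to oxygen, which takes away the group's hydrogen-bond donor, is not a neutral swap in the Hepatocyte assay: it gives a 3.4-fold higher number from compound 3 to compound 4 (0.53 log units; beyond the scatter). The oxygen ring also differs from the ring of compound 2, with a 4.4-fold higher number from compound 2 to compound 4 (0.64 log units; beyond the scatter), but not from the seven-membered ring, with a 1.5-fold lower number from compound 1 to compound 4 (0.18 log units; within the scatter). In a physicochemical assay for lipophilicity, using the shake flask method, measured as octanol-water partition, at pH 7.4 (a higher number here means a more lipophilic compound, a lower number a more polar compound), compound 3 gives 2.4 and compound 4 gives 2.6, a number 0.20 log units higher from compound 3 to compound 4 (within the scatter), and no evidence here explains the gap in removal.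

Still open, as far as these compounds go, is how a sulfur atom or a methyl-bearing nitrogen at this ring atom would compare with the nitrogen and the oxygen.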